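Adding a Methoxy Group to Compound 2

This account rests on a few compounds, and the source may have more. Where it says the series, first, only, none or still open, it means among the compounds named here.

Of the compounds shown here, two have been measured in an assay for inhibition of protein deacetylase HDAC6 (Homo sapiens), read by fluorescence; a higher number here means a weaker inhibitor, a lower number a stronger inhibitor. Compound 1, `Nc1ccccc1NC(=O)CCCCCCC(=O)Nc1cccc(-c2ccccc2)c1`, gives 50000 nM in this assay. Compound 2, `NS(=O)(=O)NCCCCCC(=O)Nc1cccc2cccnc12`, gives 390 nM in this assay. Of the two numbers, compound 2 stands lowest; the nearest is compound 1, whose number is higher by an amount well beyond the scatter, so compound 2 is the stronger inhibitor of the pair. The two differ in many places at once, so their values say nothing about any single change.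

Compound 3, `COc1cc(NC(=O)CCCCCNS(N)(=O)=O)c2ncccc2c1`, has not yet been measured. It differs from compound 2 in one place: methoxy in place of hydrogen on an aromatic carbon. For the measured compounds named here, no pair of measured compounds shows this change, so there is no measured step to lean on. The change is small in what it adds, and nothing measured points in either direction. Only a small step is therefore expected, most likely within the scatter: a 1.0-fold higher number from compound 2 to compound 3 (0.01 log units; within the scatter). Compound 3 is thus estimated to give 400 nM in this assay, with a likely range from 150 nM to 1200 nM.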

Compound 3, half-maximal inhibitory concentration: 440 nM
Compound 3: middle estimate off by 1.1-fold (0.04 log units), on the low side; measured number inside the range.
By their numbers in this assay, from the lowest: compounds 2 and 3 (each within the scatter of the next); then compound 1.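

In this assay the change amounts to a 1.1-fold higher number from compound 2 to compound 3 (0.05 log units; within the scatter) and so leaves compound 3 and compound 2 indistinguishable in this measurement. For the compounds shown here, this is the first reading at this position, an aromatic carbon of the six-membered carbon-only ring in the fused system, and it shows that the position can carry methoxy, with its two heavy atoms and one hydrogen-bond acceptor, with no shift beyond the ordinary scatter of repeated measurements. Nothing available here explains this outcome, so it stands as an observation about one group on one carbon and not as an account of how the group acts.

What the compounds shown leave open is whether this position stays as undemanding for other groups, such as an amine, a carboxylic acid or a longer ethoxy chain, since a single substituent cannot reveal a trend. It is also open whether methoxy would give a similar reading on other aromatic carbons of the shared core, as no other placement appears among these compounds.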